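Glycerol-ether pyrimidinediones: the assay floor and an amino variant

The source may hold more compounds than are shown below. What is called first, only, known or untested is meant among the compounds shown, and "the series" means these compounds.

Measured compounds:
compound 1 `Cc1cc(=O)[nH]c(=O)n1COC(CO)CO` — in a functional assay on NCI-H460 cells (Homo sapiens) for inhibition, read by MTT assay, with a stated time of 72 h (on this read-out lower numbers stand for stronger inhibition and higher numbers for weaker inhibition), compound 1 reaches only the assay limit > 100000 nM.
compound 2 `O=c1ccn(COC(CO)CO)c(=O)[nH]1` — in this assay compound 2 reaches only the assay limit > 100000 nM.
compound 3 `Cc1ccc(S(=O)(=O)Nc2ccn(C)c(=O)n2)cc1` — in this assay compound 3 reaches only the assay limit > 100000 nM.

Compound 2 stands at a limit and not at a number; every value shown for this series sits at that same limit (the limit of > 100000 nM in this assay, at which 3 of the 3 values shown sit). For the measured compounds named here, the one measured step, a step that the two limits leave unreadable from compound 1 to compound 2, is left unreadable by the two limits, so no measured step tells how large a change on the shared core can move the read-out.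

Compound 4 `Nc1cn(COC(CO)CO)c(=O)[nH]c1=O` carries the change (amino in place of hydrogen on an aromatic carbon). Going by the values given here, no measured step bears on this change, and the three limits give no foothold for a step in either direction. What they do show is that compound 1, compound 2 and compound 3 all sit at the limit, so the expectation for compound 4 is that it also sits there. Compound 4 is expected to give about 150000 nM in this assay, with a range from 30000 nM to 1000000 nM. The step from compound 2 to compound 4 is thus estimated as a step that the limit leaves unreadable from compound 2 to compound 4, that is, none beyond the scatter.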

Compound 4, half-maximal inhibitory concentration: > 100000 nM
Compound 4 was reported as a limit (the forecaster's own chance of this, stated with the estimate: 85%); the middle value does not contradict the limit.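

No step can be read from compound 2 to compound 4: both results are assay limits, not numbers. The compounds shown leave open whether amino in place of hydrogen, or any other change on the shared core, moves the read-out at all.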